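The source may hold more compounds than are shown below. What is called first, only, known or untested is meant among the compounds shown, and "the series" means these compounds.

Compound 1 `CCC(COc1ccc(Cl)cc1)OC(=O)NCc1ccccc1`: > 100000 nM
Compound 2 `CCC(COc1cccc([N+](=O)[O-])c1)OC(=O)NCc1ccccc1`: > 100000 nM

Of the compounds shown here, two have been tested in an assay for inhibition of zeta-carotene desaturase, chloroplastic/chromoplastic (Capsicum annuum), using a Dixon plot, with a stated time of 8 h (on this read-out higher numbers stand for weaker inhibition and lower numbers for stronger inhibition), and both return only limits. For compound 1 the value > 100000 nM is a limit of the assay rather than a number. For compound 2 the value > 100000 nM is likewise a limit of the assay. Compound 2 therefore stands at the edge of what this assay can report, as shown by the limit of > 100000 nM in this assay, at which 2 of the 2 values shown sit; no measurable distance separates it from compound 1, and no step between the two can be sized in either direction.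

Compound 3 `CCC(COc1cccc(C)c1)OC(=O)NCc1ccccc1` has not yet been measured. It differs from compound 2 in one place: methyl in place of nitro on an aromatic carbon. Among the measured compounds shown here, since both measured values sit at the limit, no measured step gives a direction to build on. No movement beyond the scatter is expected in this assay, and the estimated step of a number no higher from compound 2 to compound 3 (the limit leaves the size open) reflects that. Compound 3 is expected to give about 100000 nM in this assay, within a range of 30000 nM to 300000 nM, with a strong chance that again only a limit is reported.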

Compound 3, half-maximal inhibitory concentration: > 100000 nM
Compound 3: no number, only a limit; the forecaster's own chance of this, stated with the estimate: 85%; the middle value sits exactly at the limit.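

In this assay compound 3 gives > 100000 nM, which is a limit of the assay and not a number. Among the compounds shown here, no step from compound 1 or compound 2 to compound 3 can be read: the limit of > 100000 nM in this assay, at which 3 of the 3 values shown sit. The compounds shown leave open whether any change to the shared core would give a measurable value in this assay.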